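Series notes: aminophenyl for hydroxyphenyl on the anilino arm

The source may hold more compounds than are shown below. What is called first, only, known or untested is meant among the compounds shown, and "the series" means these compounds.

The pair measured so far share one core. Compound 1 `Fc1cccc(-c2nc(Nc3ccccc3Cl)c3cc(F)ccc3n2)c1` carries a 2-chlorophenyl on the anilino nitrogen. In a functional assay on U-937 cells (Homo sapiens) for cytotoxicity, read by MTT assay, with a stated time of 48 h (on this read-out lower numbers stand for stronger inhibition and higher numbers for weaker inhibition), compound 1 gives > 50000 nM, which is a limit of the assay and not a number. Compound 2 `Oc1cccc(Nc2nc(-c3cccc(F)c3)nc3ccc(F)cc23)c1` carries a 3-hydroxyphenyl in its place. In this assay compound 2 gives > 50000 nM, which is again a limit of the assay. Among the compounds with values here, the step that the two limits leave unreadable from compound 1 to compound 2 is therefore unreadable, and the only evidence on the measured values is the limit of > 50000 nM in this assay, at which 2 of the 2 values shown sit.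

Compound 3 `Nc1cccc(Nc2nc(-c3cccc(F)c3)nc3ccc(F)cc23)c1` differs from compound 2 by amino in place of hydroxy on an aromatic carbon. Within the data shown here, no measured step touches this change, so nothing in the two values gives a direction for it. Because both values sit at the limit (the limit of > 50000 nM in this assay, at which 2 of the 2 values shown sit), the expectation for compound 3 is that this assay reports a limit again rather than a number. Compound 3 is thus estimated at 50000 nM, in the range 15000 nM to 200000 nM. The expected step of a number no higher from compound 2 to compound 3 (the limit leaves the size open) is within the scatter, with no direction assigned.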

Compound 3, half-maximal inhibitory concentration: > 50000 nM
Compound 3 gave a limit, no number; the forecaster's own chance of this, stated with the estimate: 80%; the middle value sits exactly at the limit.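

In this assay compound 3 gives > 50000 nM which is a limit of the assay and not a number. The steps to compound 3 from compound 1 and compound 2 therefore cannot be read. The compounds shown leave open how hydroxy and amino compare, and whether any group on the anilino nitrogen of the shared core gives a number in this assay at all.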